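A few compounds are considered here, and "the series" means these few. Any claim that something is new, unique, unknown or untested is made for them only; others in the source may bear on it.

Measured compounds:
- compound 1 `O=S(=O)(c1ccc(F)c(F)c1)c1cnc2c(F)cccc2c1-c1ccc(Cl)cc1`: 0.28 mL/min
- compound 2 `COc1ccc(S(=O)(=O)c2cnc3c(F)cccc3c2-c2ccc(Cl)cc2)cc1`: 1.05 mL/min
- compound 3 `COc1ccc(S(=O)(=O)c2cnc3cc(F)ccc3c2-c2ccc(Cl)cc2)cc1`: 1.28 mL/min

In an ADME assay on microsomes from liver (Homo sapiens) for metabolic stability, tested at 2.5 uM (a higher number here means faster removal of the compound, a lower number slower removal), compound 3 gives the highest of the three numbers. Compound 2 sits nearest to compound 3 in this assay, and the two values lie within the scatter of each other, so no order between them is claimed. Compound 1 is furthest from compound 3, and that gap lies beyond the scatter.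

Compound 2 and compound 3 are built from the same atoms joined differently; the difference between the two cores is not broken down here.

For the measured compounds named here, the one counted change on the sulfonyl sulfur is 3,4-difluorophenyl in place of 4-methoxyphenyl on a sulfonyl sulfur, which between the two measured compounds gave a 3.8-fold lower number from compound 2 to compound 1 (0.57 log units; beyond the scatter). The same change, word for word at the same place, carries compound 3 to compound 4 `O=S(=O)(c1ccc(F)c(F)c1)c1cnc2cc(F)ccc2c1-c1ccc(Cl)cc1`: 3,4-difluorophenyl in place of 4-methoxyphenyl on a sulfonyl sulfur.

Going by the values given here, for compound 4 in this assay the expectation is a step of about the same size as the one seen from compound 2 to compound 1, because that earlier step, a 3.8-fold lower number from compound 2 to compound 1 (0.57 log units; beyond the scatter), is the only measurement of this change so far and the core of compound 3 is the only thing that differs. On that basis the step is estimated as a 3.8-fold lower number from compound 3 to compound 4 (0.58 log units; beyond the scatter).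

Compound 4 is therefore expected to give 0.34 mL/min in this assay, with a range from 0.17 mL/min to 0.7 mL/min.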

Compound 4, intrinsic clearance in a liver preparation (reported as CLH), per the amount of preparation that the assay uses: 0.01 mL/min
Compound 4: middle estimate off by 34-fold (1.53 log units), on the high side, outside the stated range (below it).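

In this assay, 3,4-difluorophenyl in place of 4-methoxyphenyl on a sulfonyl sulfur lowers the number on both cores, and the new pair gives a 130-fold lower number from compound 3 to compound 4 (2.11 log units; beyond the scatter). The direction of the change carries from one core to the other, but its size does not: the same change on two cores in this assay, a 3.8-fold lower number (0.57 log units; beyond the scatter) from compound 2 to compound 1 and a 130-fold lower number (2.11 log units; beyond the scatter) from compound 3 to compound 4, 34-fold (1.53 log units) apart, beyond the scatter of two such steps

For the compounds shown here, for this series, a step measured on one core therefore cannot be taken as the size of the same step on another core, although with only two pairs the claim reaches no further than these four compounds. The pairs do not show which feature of the cores sets the size of the step, and they do not show that the direction would hold on a third core.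

The compounds shown leave open how far the size of this step varies across other cores, and whether it follows any feature that can be read from the core. They also leave open what happens when the group on the sulfonyl sulfur is something other than an aromatic ring of carbon only, such as a morpholine or a short alkyl chain.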